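Fluoro in Place of Methoxy on the Outer Aryl Ring

The source may report more compounds than this note shows. Statements on the series, on what has been measured and on what is new or still open speak of the compounds shown alone.

For the measured compounds named here, compound 2 `COc1ccc(-c2cn3ccnc3c(-c3ccc4ncn(C5CCCCC5)c4c3)n2)cc1` has the higher of the two numbers in a functional assay on OVCAR-8 cells (Homo sapiens) for inhibition, read by sulforhodamine B assay, with a stated time of 48 h, tested at 10 uM (a higher number here means more inhibition at the concentration tested (going by the name of the read-out), a lower number less inhibition), giving 71.2%; its only neighbour, compound 1 `c1ccc(-c2cn3ccnc3c(-c3ccc4ncn(C5CCCCC5)c4c3)n2)cc1`, gives 63.9%, a gap within the scatter. Going by the values given here, the single measured step at this aromatic carbon, a number 7.3 percentage points higher from compound 1 to compound 2 (within the scatter), stayed within the scatter. Compound 3 `Fc1ccc(-c2cn3ccnc3c(-c3ccc4ncn(C5CCCCC5)c4c3)n2)cc1` differs from compound 2 by fluoro in place of methoxy on an aromatic carbon. Among the compounds with values here, no measured step covers fluoro in place of methoxy, and the one step seen here was small, so a step of a number 6.2 percentage points lower from compound 2 to compound 3 (within the scatter) is expected, none beyond the scatter. Compound 3 is therefore estimated at 65%, between 50% and 80%.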

Compound 3, a percentage reported as inhibition, at one concentration (the size of the read-out at that concentration, not a potency): 9.54%
Compound 3: middle estimate off by 55.5 percentage points, on the high side; measured number below the stated range.
By their numbers in this assay, from the lowest: compound 3; then compounds 1 and 2 (each within the scatter of the next).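

In this assay the aromatic carbon para to a large group turns out to be sensitive to what it carries: fluoro gives a number 61.7 percentage points lower from compound 2 to compound 3 (beyond the scatter) and a number 54.4 percentage points lower from compound 1 to compound 3 (beyond the scatter) while methoxy in place of hydrogen had stayed within the scatter. Of the three groups seen here, only fluoro stands apart from the others. Nothing available explains this drop.

As far as these compounds go, whether the drop is particular to fluoro remains open, since chloro, a nitrile, an amine or a carboxylic acid at this carbon could tell it apart from a general intolerance of other groups.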